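Thiophen-2-yl in place of furan-3-yl: compound 4

The source may report more compounds than this note shows. Statements on the series, on what has been measured and on what is new or still open speak of the compounds shown alone.

- compound 1 `c1ccc(-c2cc(-c3ccccn3)nc(-c3ccccn3)c2)cc1` gives 0.0014 ug/mL
- compound 2 `c1ccc(-c2cc(-c3ccco3)cc(-c3ccccn3)n2)nc1` gives 0.0024 ug/mL
- compound 3 `c1ccc(-c2cc(-c3ccoc3)cc(-c3ccccn3)n2)nc1` gives 0.0026 ug/mL

In a functional assay on HT-29 cells (Homo sapiens) for antiproliferative activity (a lower number here means a stronger inhibitor of growth, a higher number a weaker inhibitor of growth), compound 3 stands at 0.0026 ug/mL and lies within the scatter of both other compounds. Compound 4 `c1ccc(-c2cc(-c3cccs3)cc(-c3ccccn3)n2)nc1` carries thiophen-2-yl in place of furan-3-yl on an aromatic carbon and remains unmeasured. For the measured compounds named here, no compound with thiophen-2-yl has a value yet, so the nearest evidence is the three exchanges at this same place: a 1.7-fold higher number from compound 1 to compound 2 (0.23 log units; within the scatter), a 1.9-fold higher number from compound 1 to compound 3 (0.27 log units; within the scatter) and a 1.1-fold higher number from compound 2 to compound 3 (0.03 log units; within the scatter). All three stay within the scatter, so no change beyond the scatter is expected in this assay for this exchange. The estimated outcome is a 1.1-fold lower number from compound 3 to compound 4 (0.03 log units; within the scatter) and no more. For compound 4 the expected value is 0.0024 ug/mL, with an estimated range from 0.0011 ug/mL to 0.0052 ug/mL as the working figures.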

Compound 4, concentration for 50% growth inhibition: 0.0018 ug/mL
Compound 4: middle estimate off by 1.3-fold (0.12 log units), on the high side, and the stated range covers the measured number.
By their numbers in this assay, from the lowest: compounds 1, 4, 2 and 3 (each within the scatter of the next).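

In this assay, thiophen-2-yl at this place, opposite the ring nitrogen, brings sulfur into the five-membered ring and still leaves compound 4 level with the others (a 1.4-fold lower number from compound 3 to compound 4 (0.16 log units; within the scatter)), (a 1.3-fold lower number from compound 2 to compound 4 (0.12 log units; within the scatter)) and (a 1.3-fold higher number from compound 1 to compound 4 (0.11 log units; within the scatter)). Across these four compounds, phenyl, furan-2-yl, furan-3-yl and thiophen-2-yl therefore cannot be told apart at this place. Nothing available accounts for this flat result.

Open, from the compounds shown here alone, is whether this holds only for aromatic rings: an amine, a carboxylic acid or a longer alkyl chain at this place would show whether the number moves beyond the scatter.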